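The source may report more compounds than this note shows. Statements on the series, on what has been measured and on what is new or still open speak of the compounds shown alone.

Three compounds share one core and differ only in the group carried on the chain attached to the ring nitrogen. Compound 1 `O/N=C(\Nc1ccc(F)c(Br)c1)c1nonc1NCc1ccccc1` gives 230 nM in an assay for inhibition of Indoleamine 2,3-dioxygenase 1 (Homo sapiens); on this read-out higher numbers stand for weaker inhibition and lower numbers for stronger inhibition; compound 2 `COCCNc1nonc1/C(=N/O)Nc1ccc(F)c(Br)c1` gives 200 nM; compound 3 `NCCNc1nonc1/C(=N/O)Nc1ccc(F)c(Br)c1` gives 290 nM. On these numbers compound 3 is set apart from neither of the others: a 1.3-fold higher number from compound 1 to compound 3 (0.10 log units; within the scatter) and a 1.5-fold higher number from compound 2 to compound 3 (0.16 log units; within the scatter) both fall within the scatter, as does a 1.2-fold lower number from compound 1 to compound 2 (0.06 log units; within the scatter). Compound 4 `CS(=O)(=O)NCCNc1nonc1/C(=N/O)Nc1ccc(F)c(Br)c1` carries methylsulfonyl in place of hydrogen on an amine nitrogen, so that an amino group becomes methanesulfonamido. All three measured steps bear on this end of the chain, and none of them moved the number beyond the scatter. The expectation is therefore a 1.1-fold lower number from compound 3 to compound 4 (0.05 log units; within the scatter), nothing beyond the scatter. For compound 4 the estimated value is 260 nM, within a range from 120 nM to 560 nM.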

Compound 4, half-maximal inhibitory concentration: 100 nM
For compound 4 the middle estimate is 2.6-fold (0.41 log units) above the measured one, and the stated range ends above it.
By their numbers in this assay, from the lowest: compounds 4, 2, 1 and 3 (each within the scatter of the next, the first and the last beyond it).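

Among the compounds shown here, until this result, no change at this end of the chain had moved the number beyond the scatter, but methylsulfonyl on the amine nitrogen does (a 2.9-fold lower number from compound 3 to compound 4 (0.46 log units; beyond the scatter)). The methanesulfonamido end also stands apart from the phenyl group (a 2.3-fold lower number from compound 1 to compound 4 (0.36 log units; beyond the scatter)), yet not from the methoxy group, where the step stays within the scatter (a 2.0-fold lower number from compound 2 to compound 4 (0.30 log units; within the scatter)). Nothing shown accounts for the effect of this change. Open, on these data alone, is whether methylsulfonyl itself matters: an acetyl or phenylsulfonyl group on the same nitrogen would test this. As far as these compounds go, a longer chain carrying methanesulfonamido is also open.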